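Vinyl for Ethynyl on Two Different Cores

The source may hold more compounds than are shown below. What is called first, only, known or untested is meant among the compounds shown, and "the series" means these compounds.

The study compares two pairs of compounds that share one change: vinyl in place of ethynyl on an aromatic carbon. The first pair is measured. Compound 3 `C#Cc1nc2ccccc2n1C` and compound 2 `C=Cc1nc2ccccc2n1C` were tested in a functional assay on HCT-116 cells (Homo sapiens) for cytotoxicity, with a stated time of 3 days; a higher number here means a weaker inhibitor, a lower number a stronger inhibitor. In this assay compound 3 gives 19400 nM, and compound 2 gives 9500 nM. The step of a 2.0-fold lower number from compound 3 to compound 2 (0.31 log units; beyond the scatter) corresponds to vinyl in place of ethynyl on an aromatic carbon.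

Compound 1 `C#Cc1sc(-c2ccc(F)cc2)nc1C(=O)OCC` belongs to the second pair. In this assay compound 1 gives > 40000 nM, which is a limit of the assay and not a number, as recorded in the limit of > 40000 nM in this assay, at which 1 of the 3 values shown sits. The difference between the core of compound 1 and the core of compound 3 is not broken down here.

Compound 4 `C=Cc1sc(-c2ccc(F)cc2)nc1C(=O)OCC` has not yet been measured in this assay. It differs from compound 1 by vinyl in place of ethynyl on an aromatic carbon. This is the same kind of change as that from compound 3 to compound 2, but the surroundings differ: in compound 1 the place is next to the ring sulfur and next to the ring atom that bears an ethoxycarbonyl group, whereas in compound 3 it is between two ring nitrogen atoms and next to the ring atom that bears a methyl group.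

Since compound 1 gives only a limit in this assay, the expected step of a number no higher from compound 1 to compound 4 (the limit leaves the size open) is set beside a 2.0-fold lower number from compound 3 to compound 2 (0.31 log units; beyond the scatter) with low confidence. Compound 4 is expected at about 40000 nM, with a range from 15000 nM to 150000 nM.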

Compound 4, half-maximal inhibitory concentration: > 40000 nM
Compound 4 ended at the assay's limit (the forecaster's own chance of this, stated with the estimate: 60%); the middle value sits exactly at the limit.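

In this assay compound 4 gives > 40000 nM as a limit of the assay and not a number. Compound 1 stands at the same limit, so no step can be read from compound 1 to compound 4: the limit of > 40000 nM in this assay, at which 2 of the 4 values shown sit. The compounds shown leave open whether vinyl in place of ethynyl changes the number at all on the core of compound 1, and in which direction.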